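The source may report more compounds than this note shows. Statements on the series, on what has been measured and on what is new or still open speak of the compounds shown alone.

Two compounds carry a measurement in a physicochemical assay for lipophilicity; on this read-out higher numbers stand for higher lipophilicity and lower numbers for lower lipophilicity. Compound 1, built as `CC(/C=C/CC(C)CCCC(C)C)=C\C(=O)OC(C)(C)C`, gives 7.56 in this assay. Compound 2, built as `C#CCCOC(=O)/C=C(C)/C=C/CC(C)CCCC(C)(C)OC`, gives 5.2 in this assay, which places compound 2 at the lower of the two numbers, well apart from compound 1 by more than the usual scatter. Compound 3, built as `C=CCSC(=O)/C=C(C)/C=C/CC(C)CCCC(C)(C)OC`, has not yet been measured in this assay. It differs from compound 2 in one place: allylsulfanyl in place of (but-3-yn-1-yl)oxy on a carbonyl carbon. Among the measured compounds shown here, no measured pair in this set shows the effect of such an exchange, so the expectation must rest on the structures alone. The group that leaves carries one oxygen and four carbons with a triple bond, while the group that enters carries one sulfur and three carbons with a double bond. For compound 3 a modest upward step is expected, a number 0.50 log units higher from compound 2 to compound 3 (beyond the scatter), lying at the edge of or somewhat beyond the scatter. Compound 3 is therefore estimated to give 5.7 in this assay, within a range from 5.2 to 6.2.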

Compound 3, partition coefficient: 6.77
For compound 3 the middle estimate is 1.07 log units below the measured one; measured number outside the range, above it.
By their numbers in this assay, from the lowest: compound 2; then compound 3; then compound 1.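

In this assay, among the compounds shown here, allylsulfanyl in place of (but-3-yn-1-yl)oxy on a carbonyl carbon comes with a large step, a number 1.57 log units higher from compound 2 to compound 3 (beyond the scatter), and this is the first pair in the set that differs in one place. It shows that the read-out moves strongly with what is attached at this carbonyl carbon, whose other neighbours are a double-bonded chain carbon, even though the two groups match in hydrogen-bond donors and acceptors, carry no ring and have no net charge. No supporting evidence is available to explain the size of this step.

As far as these compounds go, the pair changes several things together: oxygen gives way to sulfur, the triple bond to a double bond, and the heavy-atom count falls, so it remains open which of these goes with the step, and an allyloxy or a but-3-yn-1-ylsulfanyl group on the same carbonyl carbon would help to separate them. Also open, from the compounds shown here alone, is how this assay would read with an amine attached at this carbonyl carbon, forming an amide, or with the free carboxylic acid.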